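The source may report more compounds than this note shows. Statements on the series, on what has been measured and on what is new or still open speak of the compounds shown alone.

Two amides on the shared core are measured. Compound 1 `CC(C)=CC(=O)Nc1c(C(O)(C(F)(F)F)C(F)(F)F)ccc2ccccc12` gives 46 nM in an assay on LtK cells with ATP-sensitive inward rectifier potassium channel 11 (Homo sapiens) as the target; a higher number here means that more compound is needed for the effect, a lower number that less compound is needed. Going by the values given here, compound 2 `O=C(Nc1c(C(O)(C(F)(F)F)C(F)(F)F)ccc2ccccc12)c1ccc(I)cc1` gives 154 nM in this assay and so stands at the higher of the two numbers; the one step measured, a 3.3-fold higher number from compound 1 to compound 2 (0.52 log units; beyond the scatter), replaces the alkenyl group with an aryl group on the carbonyl carbon.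

Compound 3 `COc1ccc(C(=O)Nc2c(C(O)(C(F)(F)F)C(F)(F)F)ccc3ccccc23)cc1` differs from compound 2 by methoxy in place of iodo on an aromatic carbon, on an aromatic carbon para to a large group. Among the compounds with values here, no measured step exchanges one substituent on that aromatic ring for another, so the step from compound 1 to compound 2 bears on it only indirectly, and it concerns a different kind of change. The expectation is therefore a step of a 1.0-fold lower number from compound 2 to compound 3 (0.01 log units; within the scatter) in this assay, not beyond the scatter. Compound 3 is estimated at 150 nM in this assay, with a range from 50 nM to 500 nM.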

Compound 3, half-maximal effective concentration: 417 nM
The estimate for compound 3 lay 2.8-fold (0.44 log units) below the measured number; the range from low to high includes it.
By their numbers in this assay, from the lowest: compound 1; then compound 2; then compound 3.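

Going by these compounds alone, the substituent on the aromatic carbon para to a large group matters in this assay: methoxy in place of iodo gives a 2.7-fold higher number from compound 2 to compound 3 (0.43 log units; beyond the scatter), the first measured exchange on that ring. The 4-methoxyphenyl in place of 2-methylprop-1-en-1-yl on the carbonyl carbon gives a 9.1-fold higher number from compound 1 to compound 3 (0.96 log units; beyond the scatter), a larger step than the one to 4-iodophenyl, so the cost of an aryl group in place of the alkenyl group depends on what the ring carries at this carbon. No evidence on the reason for either step is at hand.

On these data alone, with only iodo and methoxy at this carbon, it remains open whether an unsubstituted phenyl, a fluoro or an amine would lie nearer compound 2 or compound 3. Also open, as far as these compounds go, is how a longer chain on the carbonyl carbon would compare with compound 1.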